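Aryl swap on the shared core: compound 3 to compound 4

The compounds below may be only part of what the source reports. "The series", "measured", "known", "first", "only" and "open" are said of these compounds alone.

Compound 3 `CCOC(=O)c1cnn(-c2nc(-c3cccc(O)c3O)c(C#N)c(=O)n2C)c1N` stands lowest of the three numbers in hand, though within the scatter of both others: in a functional assay on microsomes for inhibition, with a stated time of 1 h (a lower number here means a stronger inhibitor, a higher number a weaker inhibitor), compound 3 gives 49 ug/mL, compound 1 `CCOC(=O)c1cnn(-c2nc(-c3ccc(OC)cc3)c(C#N)c(=O)n2C)c1N` gives 68 ug/mL and compound 2 `CCOC(=O)c1cnn(-c2nc(-c3cccs3)c(C#N)c(=O)n2C)c1N` gives 97 ug/mL. Compound 4 `CCOC(=O)c1cnn(-c2nc(-c3ccc(N(C)C)cc3)c(C#N)c(=O)n2C)c1N` differs from compound 3 by 4-(dimethylamino)phenyl in place of 2,3-dihydroxyphenyl on an aromatic carbon. Going by the values given here, the steps that bear on this are the other aryl exchanges at the same carbon: a 1.4-fold higher number from compound 1 to compound 2 (0.15 log units; within the scatter), a 1.4-fold lower number from compound 1 to compound 3 (0.14 log units; within the scatter) and a 2.0-fold lower number from compound 2 to compound 3 (0.30 log units; within the scatter), none beyond the scatter. Compound 4 is therefore expected to show no step beyond the scatter either: a 1.1-fold higher number from compound 3 to compound 4 (0.05 log units; within the scatter). For compound 4 the estimate in this assay is 55 ug/mL, with a range from 25 ug/mL to 120 ug/mL.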

Compound 4, half-maximal inhibitory concentration: 111 ug/mL
Compound 4: middle estimate off by 2.0-fold (0.30 log units), on the low side; measured number inside the range.
By their numbers in this assay, from the lowest: compounds 3, 1, 2 and 4 (each within the scatter of the next, the first and the last beyond it).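

In this assay this aryl position gives its first step beyond the scatter with a 2.3-fold higher number from compound 3 to compound 4 (0.36 log units; beyond the scatter) for 4-(dimethylamino)phenyl in place of 2,3-dihydroxyphenyl. The other new steps, a 1.1-fold higher number from compound 2 to compound 4 (0.06 log units; within the scatter) and a 1.6-fold higher number from compound 1 to compound 4 (0.21 log units; within the scatter) for dimethylamino in place of methoxy, stay within the scatter, so only the two ends of the order separate. No measured property of these groups is at hand to explain the step.

Open, on these data alone, is whether the gap belongs to the 2,3-dihydroxyphenyl or to the 4-(dimethylamino)phenyl. A plain phenyl or a 3-hydroxyphenyl on this carbon would bear on that.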